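This account rests on a few compounds, and the source may have more. Where it says the series, first, only, none or still open, it means among the compounds named here.

Compound 2 `CN(C)CCn1c(=O)c(=Cc2ccc(F)cc2F)s/c1=C1\C(=O)Nc2cc(F)ccc21` carries the shared core with a 2-(dimethylamino)ethyl chain on the aromatic nitrogen and a 2,4-difluorophenyl group on the double-bonded chain carbon. In a functional assay on NCI-H460 cells (Homo sapiens) for inhibition, read by MTT assay, with a stated time of 72 h (a lower number here means a stronger inhibitor, a higher number a weaker inhibitor), compound 2 gives 3200 nM, the highest of the three numbers in hand. Its nearest neighbour is compound 1 `COc1ccc(C=c2s/c(=C3\C(=O)Nc4cc(F)ccc43)n(CCN(C)C)c2=O)cc1`, which in this assay gives 2200 nM; the step of a 1.5-fold higher number from compound 1 to compound 2 (0.16 log units; within the scatter) lies within the scatter. Furthest away is compound 3 `CCN(CC)CCCn1c(=O)c(=Cc2ccc(O)cc2)s/c1=C1\C(=O)Nc2ccc(C)cc21`, which in this assay gives 260 nM; no single-point step connects it to compound 2, since it differs in the chain, the aryl group and the core substituent at once.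

Compound 4 `CCN(CC)CCCn1c(=O)c(=Cc2ccc(F)cc2F)s/c1=C1\C(=O)Nc2cc(F)ccc21` is the next member: (diethylamino)methyl in place of dimethylamino on a saturated chain carbon, two bonds along the chain from an aromatic nitrogen. Among the compounds with values here, compound 3 is the only measured compound bearing the 3-(diethylamino)propyl chain, and its low number cannot be assigned to the chain alone given the other two differences. Within the data shown here, the one measured step, from compound 1 to compound 2, concerns the aryl group and does not bear on this change. Among the measured compounds shown here, with no step on the chain available, the expectation for compound 4 in this assay is a number close to compound 2, with a 1.8-fold lower number from compound 2 to compound 4 (0.25 log units; within the scatter) not expected to exceed the scatter, and the estimate for compound 4 is 1800 nM within a range of 600 nM to 5000 nM.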

Compound 4, half-maximal inhibitory concentration: 2330 nM
Compound 4: middle estimate off by 1.3-fold (0.11 log units), on the low side; measured number inside the range.
By their numbers in this assay, from the lowest: compound 3; then compounds 1, 4 and 2 (each within the scatter of the next).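

Within the data shown here, on the saturated chain carbon, two bonds along the chain from an aromatic nitrogen, a single-point change can now be read for the first time: in this assay, replacing dimethylamino with (diethylamino)methyl gives a 1.4-fold lower number from compound 2 to compound 4 (0.14 log units; within the scatter), so with the 2,4-difluorophenyl group and the rest of the core unchanged, going from 3 to 6 heavy atoms in this group produces no readable difference. Among these compounds, this holds only for this one pair, and compound 3 gives 260 nM in this assay but differs from compound 4 in both the aryl group and the core substituent, so no single step links the two and its number remains unassigned. No measurement in hand offers an explanation for this result.

Still open, on these data alone, is whether the same chain change would stay within the scatter with a 4-hydroxyphenyl or 4-methoxyphenyl group in place of 2,4-difluorophenyl, and which of the aryl group and the core substituent bears on the number of compound 3. Also open, as far as these compounds go, is how this position responds to a chain ending in a morpholine or a carboxylic acid, or to a longer chain such as 4-(diethylamino)butyl.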